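The source may report more compounds than this note shows. Statements on the series, on what has been measured and on what is new or still open speak of the compounds shown alone.

Values in a functional assay on MOLT-4 cells (Homo sapiens) (a higher number here means a weaker inhibitor, a lower number a stronger inhibitor), for the series so far

compound 1 `O=C(/C=C/c1ccc(F)cc1)Oc1ccc(/C=C2\CCCCC2=O)cc1` gives 26600 nM
compound 2 `O=C(/C=C/c1ccc(Br)cc1)Oc1ccc(/C=C2\CCCCC2=O)cc1` gives 180000 nM
compound 3 `Cc1ccc(/C=C/C(=O)Oc2ccc(/C=C3\CCCC(CN(C)C)C3=O)cc2)cc1` gives 3390 nM

Compound 2 has the highest number of the three and is the weakest measured inhibitor here. The change to compound 4 `CN(C)CC1CCC/C(=C\c2ccc(OC(=O)/C=C/c3ccc(Br)cc3)cc2)C1=O` is (dimethylamino)methyl in place of hydrogen on a saturated ring carbon and reads as (dimethylamino)methyl in place of hydrogen on a saturated ring carbon.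

Among the compounds with values here, no measured step isolates this change. Within the data shown here, the only step available is a 6.8-fold higher number from compound 1 to compound 2 (0.83 log units; beyond the scatter) and concerns bromo in place of fluoro. Compound 4 keeps the bromo of compound 2, so that step shows only how far one change has moved the series. Among the measured compounds shown here, the closest evidence is compound 3 at 3390 nM as the only measured compound carrying (dimethylamino)methyl. It also has methyl where compound 2 has bromo, so its lower value cannot be assigned to one group alone.

In this assay a large step to a lower number, beyond the scatter, is therefore expected. The estimate amounts to a 30-fold lower number from compound 2 to compound 4 (1.48 log units; beyond the scatter) as an expected move. For compound 4 the estimated value is 6000 nM with an expected range of 1500 nM to 30000 nM in this read-out.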

Compound 4, half-maximal inhibitory concentration: 3060 nM
Beside the measured number, compound 4's estimate is 2.0-fold (0.29 log units) above it; the range from low to high includes it.
By their numbers in this assay, from the lowest: compounds 4 and 3 (each within the scatter of the next); then compound 1; then compound 2.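

In this assay, within the data shown here, the step from hydrogen to (dimethylamino)methyl on a saturated ring carbon of the six-membered non-aromatic ring reads as a 59-fold lower number from compound 2 to compound 4 (1.77 log units; beyond the scatter) and is the first reading of this group with nothing else changed. Among these compounds, with (dimethylamino)methyl in place, moving from methyl to bromo gives a 1.1-fold lower number from compound 3 to compound 4 (0.04 log units; within the scatter) and so shows no readable difference between these two aromatic substituents, while the one earlier aromatic step, without the group, was a 6.8-fold higher number from compound 1 to compound 2 (0.83 log units; beyond the scatter) and concerned fluoro and bromo rather than methyl. Nothing measured here speaks to the reason for the size of the step from hydrogen to (dimethylamino)methyl.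

Going by these compounds, the step from hydrogen to (dimethylamino)methyl is read on a single pair with bromo on the aromatic carbon, so whether it holds at the same size with fluoro on that carbon stays open. Also open, on these data alone, is what the step needs from the group itself: a morpholine, a primary amine or a carboxylic acid on the same saturated ring carbon would separate the dimethylamino end from the added chain.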